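Chain extension at the ring carbon of compound 3

The compounds below may be only part of what the source reports. "The series", "measured", "known", "first", "only" and "open" are said of these compounds alone.

Compound 3 `CC1(c2ccccc2)NC(=O)N(Cc2ccc(C(=O)NO)cc2)C1=O` gives the highest number of the three measured in an assay on isolated protein for inhibition of protein deacetylase HDAC6 (Homo sapiens), read by fluorescence, with stated times of 10 min and 2 h (on this read-out lower numbers stand for stronger inhibition and higher numbers for weaker inhibition), at 74.9 nM. Compound 1 `COc1ccc(CN2CC(=O)N(Cc3ccc(C(=O)NO)cc3)C2=O)cc1` gives 28.2 nM and compound 2 `CC(C)(C)c1ccc(CN2CC(=O)N(Cc3ccc(C(=O)NO)cc3)C2=O)cc1` gives 40.7 nM; the gap from compound 3 to compound 2 lies within the scatter, that to compound 1 beyond it. Among the measured compounds shown here, the only single-point step measured, a 1.4-fold higher number from compound 1 to compound 2 (0.16 log units; within the scatter), swaps a substituent on an aromatic carbon and stays within the scatter. Compound 4 `CCCC1(c2ccccc2)NC(=O)N(Cc2ccc(C(=O)NO)cc2)C1=O` differs from compound 3 by ethyl in place of hydrogen on a saturated chain carbon bound to a saturated ring carbon. For the measured compounds named here, no measured step touches this chain, and the one step available is small, so no movement beyond the scatter is expected in this assay; the estimated step is a 1.1-fold higher number from compound 3 to compound 4 (0.03 log units; within the scatter). For compound 4 the expected value is 80 nM, in the range 30 nM to 220 nM.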

Compound 4, half-maximal inhibitory concentration: 50.9 nM
Compound 4: the middle estimate sits 1.6-fold (0.20 log units) above what was measured; the range from low to high includes it.
By their numbers in this assay, from the lowest: compounds 1, 2, 4 and 3 (each within the scatter of the next, the first and the last beyond it).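

Ethyl in place of hydrogen on a saturated chain carbon bound to a saturated ring carbon gives a 1.5-fold lower number from compound 3 to compound 4 (0.17 log units; within the scatter) and so leaves the reading in this assay within the scatter. Among the compounds shown here, this is the first single-point step read on this chain, the earlier one being on an aromatic carbon, and methyl to propyl is tolerated here without a movement beyond the scatter. No evidence at hand accounts for this step.

Going by these compounds, whether a longer chain, an amine or a carboxylic acid in place of the propyl would also stay within the scatter remains open.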